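A few compounds are considered here, and "the series" means these few. Any claim that something is new, unique, unknown or untested is made for them only; others in the source may bear on it.

Values in a functional assay on HepG2 cells (Homo sapiens) for antiproliferative activity, read by MTT assay, with a stated time of 72 h (on this read-out lower numbers stand for stronger inhibition and higher numbers for weaker inhibition), so far:
- compound 1 `COc1cc2c(Nc3cccc(C#N)c3)ncnc2cc1OCCCN1CCCCC1` gives 29500 nM
- compound 2 `COc1cc2c(Nc3cccc(C#N)c3)ncnc2cc1OCCCN1CCC(C)CC1` gives 18200 nM
- compound 3 `CCN1CCN(CCCOc2cc3ncnc(Nc4cccc(C#N)c4)c3cc2OC)CC1` gives 13700 nM

Two gaps place the third entry: a 1.3-fold lower number from compound 2 to compound 3 (0.12 log units; within the scatter) and a 2.2-fold lower number from compound 1 to compound 3 (0.33 log units; beyond the scatter) in this series. Next is compound 4 `CCN1CCN(CCCOc2cc3ncnc(Nc4ccccc4C#N)c3cc2OC)CC1`, with 2-cyanophenyl in place of 3-cyanophenyl on a nitrogen on an aromatic ring as its only change. The measured steps, a 1.6-fold lower number from compound 1 to compound 2 (0.21 log units; within the scatter) among them, leave the cyanophenyl group untouched, so none tests this change. They give no direction, and no step beyond the scatter is expected in this assay here. The estimate is a 1.3-fold higher number from compound 3 to compound 4 (0.12 log units; within the scatter) as the expected step. For compound 4 the expected value is 18000 nM with an estimated range from 7000 nM to 45000 nM for repeat measurements.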

Compound 4, half-maximal inhibitory concentration: 2110 nM
Estimate against measurement, compound 4: 8.5-fold (0.93 log units) above; the measured number lies below the stated range.
By their numbers in this assay, from the lowest: compound 4; then compounds 3, 2 and 1 (each within the scatter of the next, the first and the last beyond it).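

In this assay, the nitrile's placement on the phenyl group matters: 2-cyanophenyl in place of 3-cyanophenyl on a nitrogen on an aromatic ring gives a 6.5-fold lower number from compound 3 to compound 4 (0.81 log units; beyond the scatter) with the same atoms joined differently. This step is larger than any printed among compounds 1, 2 and 3, whose changes lie elsewhere in the structure. No supporting measurement is available to explain this result.

Going by these compounds, whether the same step appears with piperidin-1-yl or 4-methylpiperidin-1-yl on the chain remains open. Also open, on these data alone, is whether 4-cyanophenyl, 2-chlorophenyl or 2-methoxyphenyl would match 2-cyanophenyl.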